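This account rests on a few compounds, and the source may have more. Where it says the series, first, only, none or still open, it means among the compounds named here.

Among the compounds with values here, compound 2 `Cc1ccc([C@H]2CC(c3cc4ccccc4oc3=O)=NN2c2ccccc2)cc1` gives 38% in a functional assay on the whole organism (strain albino) for inhibition, with Rattus norvegicus as the target, read by paw edema, with stated times of 1 h and 4 h, at a dose of 200 mg/kg by the oral route (on this read-out lower numbers stand for less inhibition and higher numbers for more inhibition at the one dose given (going by the name of the read-out)), and of the two numbers measured so far it stands together with compound 1 `COc1ccc([C@H]2CC(c3cc4ccccc4oc3=O)=NN2c2ccccc2)cc1`, which gives 36.2% in this assay: the step of a number 1.8 percentage points higher from compound 1 to compound 2 (within the scatter) is within the scatter, so the two cannot be told apart on these numbers. Compound 3 `O=c1oc2ccccc2cc1C1=NN(c2ccccc2)[C@@H](c2ccc(F)cc2)C1` is the next member and differs from compound 2 by fluoro in place of methyl on an aromatic carbon. Within the data shown here, no measured step swaps methyl for fluoro anywhere. Among the measured compounds shown here, the only step that bears on the change is the methoxy-to-methyl exchange on the same aromatic carbon, a number 1.8 percentage points higher from compound 1 to compound 2 (within the scatter), which stayed within the scatter; it shows that the one earlier exchange of a small group at this position left the read-out in this assay where it was. For the measured compounds named here, with no step of its own to lean on, the expectation for compound 3 is no step beyond the scatter. Compound 3 is therefore estimated at 37% in this assay, with a range from 27% to 47%. The expected step is a number 1 percentage points lower from compound 2 to compound 3 (within the scatter).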

Compound 3, a percentage reported as inhibition, in the whole organism at one dose (the size of the read-out at that dose, not a potency): 66.7%
For compound 3 the middle estimate is 29.7 percentage points below the measured one, and the stated range ends below it.
By their numbers in this assay, from the lowest: compounds 1 and 2 (each within the scatter of the next); then compound 3.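

Notes on the group at the aromatic carbon para to a large group: this position does move the read-out in this assay, with fluoro in place of methyl giving a number 28.7 percentage points higher from compound 2 to compound 3 (beyond the scatter) and fluoro in place of methoxy giving a number 30.5 percentage points higher from compound 1 to compound 3 (beyond the scatter), whereas the only earlier exchange here left compound 1 and compound 2 inseparable. Methyl and fluoro each count one heavy atom, with no ring, no hydrogen-bond donor or acceptor and no net charge, so these counts do not separate compound 2 from compound 3, and among the three groups shown only fluoro stands apart. No measurement is available that explains this difference.

Going by these compounds, whether chloro or bromo at the same place would stand with fluoro, or with methyl and methoxy, remains open, as does the outcome with an amine or a carboxylic acid there. Also open, on these data alone, is whether the gap between compound 3 and the other two persists at other doses, since the read-out here comes from a single dose and gives the size of the effect, not a potency.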